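A Second Methoxy on an Already Weak Binder

This account rests on a few compounds, and the source may have more. Where it says the series, first, only, none or still open, it means among the compounds named here.

Three compounds sharing one core were tested in an assay on membranes from brain for binding affinity to adenosine receptor A1 (Rattus norvegicus), read by radioligand binding; a lower number here means a stronger inhibitor, a higher number a weaker inhibitor:

Compound 1 `Cc1nn(C)c2c(O)nc(-c3ccncc3)nc12`: 950 nM
Compound 2 `Cc1nn(C)c2c(O)nc(-c3ccccc3)nc12`: 1020 nM
Compound 3 `COc1ccccc1-c1nc(O)c2c(n1)c(C)nn2C`: 10000 nM

Compound 3 stands at the highest number of the three, so it is the weakest inhibitor among them; compound 1 and compound 2 both sit well below it, beyond the scatter. The step of a 1.1-fold higher number from compound 1 to compound 2 (0.03 log units; within the scatter) shows that swapping pyridin-4-yl for phenyl changed nothing of note. The step of a 9.8-fold higher number from compound 2 to compound 3 (0.99 log units; beyond the scatter) shows that adding a methoxy group to that phenyl ring made the number clearly worse.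

Compound 4 `COc1ccc(-c2nc(O)c3c(n2)c(C)nn3C)c(OC)c1` carries a second methoxy on the same ring: methoxy in place of hydrogen on an aromatic carbon. For the measured compounds named here, only one measured step bears on this change, namely a 9.8-fold higher number from compound 2 to compound 3 (0.99 log units; beyond the scatter), where a first methoxy on the ring weakened binding by a modest amount. A further methoxy, now at a different position on that ring, might push the number up again or leave it roughly where it is; nothing in the measured set suggests a recovery of potency. The expected step is therefore a 1.5-fold higher number from compound 3 to compound 4 (0.18 log units; within the scatter), upward or flat rather than downward. For compound 4 the estimate in this assay is 15000 nM, with a range from 5000 nM to 40000 nM.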

Compound 4, half-maximal inhibitory concentration: 5430 nM
For compound 4 the middle estimate is 2.8-fold (0.44 log units) above the measured one, and the stated range covers the measured number.
By their numbers in this assay, from the lowest: compounds 1 and 2 (each within the scatter of the next); then compounds 4 and 3 (each within the scatter of the next).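

In this assay, the new methoxy sits on an aromatic carbon of the ring, meta to a methoxy group and para to a large group, and it gives a 1.8-fold lower number from compound 3 to compound 4 (0.27 log units; within the scatter). This position therefore accepts a methoxy in place of hydrogen with no readable shift in either direction, at least on a ring that already carries one methoxy. The earlier methoxy step, a 9.8-fold higher number from compound 2 to compound 3 (0.99 log units; beyond the scatter), lies beyond the scatter while the new one lies within it, so on this ring, adding a methoxy does not have the same effect in every case, although two steps are too few to support a general rule. Nothing available here accounts for this result.

Going by these compounds, it remains open whether a methoxy at this position would leave the number just as flat on the ring of compound 2, which carries no first methoxy. On these data alone, it also remains open whether this position would accept a different group just as readily, such as an amine or a carboxylic acid, or whether such a group would move the number beyond the scatter.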